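Bromo in Place of Trifluoromethyl: One Substitution, One Estimate

The compounds below may be only part of what the source reports. "The series", "measured", "known", "first", "only" and "open" are said of these compounds alone.

Compound 1, `COc1cc2ncnc(Nc3ccc(Br)cc3Cl)c2c(OC)c1OC`, gives "not determined" (no result reported) in a functional assay on BGC-823 cells (Homo sapiens) for inhibition, read by MTT assay, with a stated time of 72 h, tested at 10 uM (a lower number here means less inhibition of growth, a higher number more inhibition of growth at the concentration tested), so no result is reported for it.
Compound 2, `COc1cc2ncnc(Nc3ccc(C(F)(F)F)cc3)c2c(OC)c1OC`, gives 17.4% in this assay.

Among the measured compounds shown here, compound 2 is therefore the only compound with a number in this assay; compound 1 contributes no value to compare against, so no pair of measured compounds shows how any single change moves the read-out. Compound 3, `COc1cc2ncnc(Nc3ccc(Br)cc3)c2c(OC)c1OC`, differs from compound 2 by bromo in place of trifluoromethyl on an aromatic carbon. For the measured compounds named here, with no measured step available, the expectation for compound 3 rests on compound 2 alone. The change from compound 2 to compound 3 is expected to produce a step of a number 2.6 percentage points higher from compound 2 to compound 3 (within the scatter) in this assay, a shift that would sit within the usual scatter of repeated measurements rather than a clear move in either direction. Compound 3 is accordingly estimated at 20% in this assay, with a plausible range from 5% to 40%.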

Compound 3, percent growth inhibition at one concentration: 32.6%
For compound 3 the middle estimate is 12.6 percentage points below the measured one, and the stated range covers the measured number.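

In this assay, among the compounds shown here, bromo in place of trifluoromethyl gives a number 15.2 percentage points higher from compound 2 to compound 3 (beyond the scatter), the first reading of any single change. It shows that growth inhibition at the concentration tested responds to the group held on this aromatic carbon, para to a large group, and that here the exchange of a group of 4 heavy atoms for one of 1 heavy atom goes with the higher number. Nothing available accounts for the size or direction of this step.

Going by these compounds, with a single pair, it stays open whether another group at this place, such as an amine, a nitrile or a carboxylic acid, would read closer to compound 2 or to compound 3. On these data alone, it also stays open whether the same step would appear on other cell lines or at other concentrations.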